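This account rests on a few compounds, and the source may have more. Where it says the series, first, only, none or still open, it means among the compounds named here.

Compound 1 `Cc1cn([C@H]2C[C@H](n3cc(COc4ccc5oc(=O)ccc5c4)nn3)[C@@H](CO)O2)c(=O)[nH]c1=O` and compound 2 `Cc1cn([C@H]2C[C@H](n3cc(CNC(=O)c4ccc(S(N)(=O)=O)cc4)nn3)[C@@H](CO)O2)c(=O)[nH]c1=O` share one core and were both tested in an assay on isolated protein for inhibition of carbonic anhydrase 5A, mitochondrial (Homo sapiens), read by stopped-flow, with a stated time of 15 min; on this read-out higher numbers stand for weaker inhibition and lower numbers for stronger inhibition. In this assay compound 1 gives 57.8 nM. In this assay compound 2 gives 1470 nM. Compound 2 therefore has the higher of the two numbers, and its gap to compound 1 lies beyond the usual scatter, so compound 2 is the weaker inhibitor of the pair. Compound 3 `Cc1cn([C@H]2C[C@H](n3cc(CNC(=O)Nc4cccc(S(N)(=O)=O)c4)nn3)[C@@H](CO)O2)c(=O)[nH]c1=O` has not yet been measured. It differs from compound 2 in one place: (3-sulfamoylphenyl)amino in place of 4-sulfamoylphenyl on a carbonyl carbon. Within the data shown here, no measured pair shows this same change, so its effect cannot be read from the data at hand. The expected step is a 2.5-fold lower number from compound 2 to compound 3 (0.39 log units; beyond the scatter), a moderate move toward a lower number that would just exceed the scatter, held with little certainty. Compound 3 is estimated at 600 nM, with a likely range from 100 nM to 4000 nM.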

Compound 3, inhibition constant: 3240 nM
Compound 3: the middle estimate sits 5.4-fold (0.73 log units) below what was measured; the range from low to high includes it.
By their numbers in this assay, from the lowest: compound 1; then compound 2; then compound 3.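

In this assay the swap of 4-sulfamoylphenyl for (3-sulfamoylphenyl)amino on the carbonyl carbon gives a 2.2-fold higher number from compound 2 to compound 3 (0.34 log units; beyond the scatter) and so weakens inhibition modestly. Among these compounds, the earlier compounds offered no pair differing at this place alone, so this is the first sign that the group here affects the read-out. Nothing measured here gives a reason for the shift.

On these data alone, the change does two things at once: it adds an amino nitrogen on the carbonyl carbon, and it moves the sulfamoyl group from the 4 to the 3 position of the ring, so the share of each in the step stays open. A (4-sulfamoylphenyl)amino group on the same carbonyl carbon would separate the two, and a carboxylic acid in place of the sulfamoyl group remains an open case as well.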